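Methyl in place of cyclohexyl: expected lipophilicity shift

The compounds below may be only part of what the source reports. "The series", "measured", "known", "first", "only" and "open" are said of these compounds alone.

Measured compounds:
- compound 1, `O=C(C1CCCCC1)N1CCC(C(=O)N2N=CCC2c2ccccc2)CC1`: 5.4
- compound 2, `O=C(C1CCN(c2cccnn2)CC1)N1N=CC[C@H]1c1ccccc1`: 3.4
- compound 3, `CC(C)C(=O)N1N=CCC1c1ccccc1`: 4.4

In a physicochemical assay for lipophilicity, read by HPLC, measured as chromatographic lipophilicity, at pH 7.4 (on this read-out lower numbers stand for lower lipophilicity and higher numbers for higher lipophilicity), compound 1 gives 5.4, the highest of the three numbers. Compound 3 gives 4.4, a number below compound 1 by a gap beyond the scatter. Compound 2 gives 3.4, the lowest of the three, again separated from compound 1 by more than the scatter. Among the compounds with values here, no two of the measured compounds differ in a single place, so no single-change step within the measured set can be read off; the three values show only that the series spans a wide range on this read-out.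

Compound 4, `CC(=O)N1CCC(C(=O)N2N=CCC2c2ccccc2)CC1`, has not been measured. Relative to compound 1 the change is methyl in place of cyclohexyl on a carbonyl carbon. Five carbon atoms and a ring of carbon only are removed and nothing polar is added, so the step is expected to be a marked fall, well beyond the scatter, towards the lower part of the range spanned by compound 2 and compound 3. The step of a number 2.10 log units lower from compound 1 to compound 4 (beyond the scatter) is the estimated size of that fall. For compound 4 the expected value is 3.3, with a range from 2.6 to 4.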

Compound 4, distribution coefficient: 2.5
For compound 4 the middle estimate is 0.80 log units above the measured one; the whole stated range lies above it.
By their numbers in this assay, from the lowest: compound 4; then compound 2; then compound 3; then compound 1.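

In this assay, within the data shown here, methyl in place of cyclohexyl on a carbonyl carbon gives the first single-change step: a number 2.90 log units lower from compound 1 to compound 4 (beyond the scatter). The step is large, so the read-out of this series responds strongly to the group at this position, even though the rest of the structure stays the same and the change neither adds nor removes a hydrogen-bond donor or acceptor. No supporting data bear on why the step has this size.

Cyclohexyl and methyl are only two points at this position, so it remains open whether the read-out falls smoothly or abruptly between them, and whether a straight butyl chain would behave like the ring of carbon it resembles in size or fall somewhere along the step. Also open, from the compounds shown here alone, is how far the read-out would move with an amine or a carboxylic acid on the same carbonyl carbon, and whether the same swap gives a step of similar size on a different core.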